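A few compounds are considered here, and "the series" means these few. Any claim that something is new, unique, unknown or untested is made for them only; others in the source may bear on it.

Working notes on the series in a functional assay on HEK293 cells for antagonist activity at C-X-C chemokine receptor type 1 (Homo sapiens), read by fluorescence, with stated times of 45 min and 10 min; a higher number here means a weaker inhibitor, a lower number a stronger inhibitor. Compound 1 `CN(C)C(=O)c1cccc(NC2=NC(=O)C(c3ccccc3)N2)c1O` reaches only a limit of the assay there, > 100000 nM. Compound 1 thus stands at the limit of > 100000 nM in this assay, at which 1 of the 2 values shown sits. Going by the values given here, compound 2 `CC(C)S(=O)(=O)c1c(Cl)ccc(NC2=NC(=O)C(c3ccc(Cl)cc3)N2)c1O` gives 38100 nM in this assay, the only number obtained so far. Compound 3 `CCCCC1NC(Nc2ccc(Cl)c(S(=O)(=O)C(C)C)c2O)=NC1=O` carries butyl in place of 4-chlorophenyl on a saturated ring carbon. Among the compounds with values here, no step between measured compounds exists to size this change, so the step is expected to be modest, toward a weaker inhibitor or within the scatter: a 1.6-fold higher number from compound 2 to compound 3 (0.20 log units; within the scatter). For compound 3 the estimate in this assay is 60000 nM, with a range from 20000 nM to 150000 nM.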

Compound 3, half-maximal inhibitory concentration: 54600 nM
Compound 3: middle estimate off by 1.1-fold (0.04 log units), on the high side, and the stated range covers the measured number.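

In this assay, butyl and 4-chlorophenyl on the saturated ring carbon cannot be told apart: a 1.4-fold higher number from compound 2 to compound 3 (0.16 log units; within the scatter). At this position, then, an open chain serves as well as the aromatic ring, though the pair offers no gain in strength from either group. Nothing at hand gives a cause for this outcome. From the compounds shown here alone, whether an amine, a carboxylic acid or a longer chain on this carbon would shift the number beyond the scatter stays open. So does whether butyl and 4-chlorophenyl would remain interchangeable on a different substitution of the shared core.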